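The compounds below may be only part of what the source reports. "The series", "measured", "known", "first", "only" and "open" are said of these compounds alone.

Compound 1 `COc1cc(C(=O)c2sc(-c3ccc(Br)cc3)cc2N)cc(OC)c1OC` is the weaker of the two measured compounds in a functional assay on MOLT-4 cells (Homo sapiens) for antiproliferative activity (a higher number here means a weaker inhibitor, a lower number a stronger inhibitor), where compound 1 gives 92 nM. Its nearest neighbour is compound 2 `COc1cc(C(=O)c2sc(-c3ccc(Cl)cc3)cc2N)cc(OC)c1OC`, which in this assay gives 77 nM; the step of a 1.2-fold lower number from compound 1 to compound 2 (0.08 log units; within the scatter) shows that swapping one halogen for another at the same position changes little. Compound 3 `COc1cc(C(=O)c2sc(-c3ccccc3Cl)cc2N)cc(OC)c1OC` has not yet been measured. It differs from compound 1 as follows: 2-chlorophenyl in place of 4-bromophenyl on an aromatic carbon. For the measured compounds named here, the only measured step, from compound 1 to compound 2, concerns the identity of the halogen and not its position on the phenyl ring, so it bears on the present change only in part. Nothing measured here speaks to moving the halogen, so no direction can be expected with confidence. Compound 3 is therefore estimated near compound 1, with a step of a 1.4-fold higher number from compound 1 to compound 3 (0.15 log units; within the scatter) and a wide range, giving an expected 130 nM between 40 nM and 450 nM.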

Compound 3, half-maximal inhibitory concentration: 17 nM
Compound 3: the middle estimate sits 7.6-fold (0.88 log units) above what was measured; the whole stated range lies above it.
By their numbers in this assay, from the lowest: compound 3; then compounds 2 and 1 (each within the scatter of the next).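

In this assay, the exchange of 4-chlorophenyl for 2-chlorophenyl keeps the halogen the same and alters only its place on the phenyl ring, and it gives a 4.5-fold lower number from compound 2 to compound 3 (0.66 log units; beyond the scatter). The change from 4-bromophenyl to 2-chlorophenyl points the same way, with a 5.4-fold lower number from compound 1 to compound 3 (0.73 log units; beyond the scatter), whereas the exchange of bromo for chloro in the earlier pair stayed within the scatter, so among these compounds the place of the halogen on the phenyl ring, not its identity, is what sets compound 3 apart. No evidence is at hand that accounts for this difference.

As far as these compounds go, whether bromo in place of the chloro of 2-chlorophenyl would give a similar number remains open. So does the outcome for a methoxy group or a methyl group at that place on the phenyl ring, or for a phenyl ring with no halogen at all.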